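This account rests on a few compounds, and the source may have more. Where it says the series, first, only, none or still open, it means among the compounds named here.

Measured in a functional assay on HCT-116 cells (Homo sapiens) for inhibition, read by MTT assay, with a stated time of 48 h; on this read-out higher numbers stand for weaker inhibition and lower numbers for stronger inhibition:
compound 1, `COc1ccc(CN(C(=O)C(C)Br)c2cc(OC)c(OC)c(OC)c2)cc1O`: 140 nM
compound 2, `COC(=O)c1cc(CNc2cc(OC)c(OC)c(OC)c2)ccc1OC`: 38100 nM

Compound 1 has the lowest number of the two; compound 2 sits at a higher number, a gap beyond the scatter. Going by the values given here, no step between measured compounds that differ in one place is available here. Compound 3, `CCC(=O)N(Cc1ccc(OC)c(O)c1)c1cc(OC)c(OC)c(OC)c1`, differs from compound 1 by hydrogen in place of bromo on a saturated chain carbon bound to a carbonyl carbon and a saturated chain carbon. Nothing measured mirrors this change, so its size is open; a move to a higher number, beyond the scatter, is expected, as an 18-fold higher number from compound 1 to compound 3 (1.25 log units; beyond the scatter). Compound 3 is estimated at 2500 nM, with a range from 400 nM to 20000 nM.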

Compound 3, half-maximal inhibitory concentration: 61 nM
For compound 3 the middle estimate is 41-fold (1.61 log units) above the measured one, and the stated range ends above it.
By their numbers in this assay, from the lowest: compound 3; then compound 1; then compound 2.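

On this assay the change from (1-bromoethyl)carbonyl to propanoyl gives a 2.3-fold lower number from compound 1 to compound 3 (0.36 log units; beyond the scatter) as a modest step. Bromo on this saturated chain carbon bound to a carbonyl carbon and a saturated chain carbon is thus not needed for a low number, and its replacement by hydrogen does not cost activity here. No measurement shown accounts for this step.

Still open, from the compounds shown here alone, is whether a longer chain such as butanoyl keeps the low number. Also open, going by these compounds, is how chloro or an amine on this carbon compares with hydrogen.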